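Swapping an Ester Tail for a Carbamate Tail

The source may report more compounds than this note shows. Statements on the series, on what has been measured and on what is new or still open speak of the compounds shown alone.

Compound 2 `COC(=O)CCCNC(=O)CN1CN(c2ccccc2)C2(CCN(C(=O)c3ccc(C4CCCCC4)cc3)CC2)C1=O` and compound 1 `CCC1CCCN(C(=O)CN2CN(c3ccccc3)C3(CCN(C(=O)c4ccc(C5CCCCC5)cc4)CC3)C2=O)C1` share one core and differ in a single place on one amide carbonyl. In an assay on HEK293 cells for displacement of a labelled ligand from NPC1-like intracellular cholesterol transporter 1 (Homo sapiens) (a higher number here means a weaker inhibitor, a lower number a stronger inhibitor), compound 1 gives 2600 nM, and compound 2 gives 2500 nM. For the measured compounds named here, on the numbers so far compound 2 holds the lowest of the two, yet the step of a 1.0-fold lower number from compound 1 to compound 2 (0.02 log units; within the scatter) is within the scatter, so the two compounds cannot be separated by these measurements.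

Compound 3 `CC(C)(C)OC(=O)NCNC(=O)CN1CN(c2ccccc2)C2(CCN(C(=O)c3ccc(C4CCCCC4)cc3)CC2)C1=O` has not yet been measured. It differs from compound 2 by (tert-butoxycarbonyl)amino in place of 2-(methoxycarbonyl)ethyl on a saturated chain carbon bound to an amide-type nitrogen. Going by the values given here, only one measured step touches this region of the molecule, namely a 1.0-fold lower number from compound 1 to compound 2 (0.02 log units; within the scatter), and that replacement left the number where it was. No further guidance exists for this part of the structure, so no step beyond the scatter is expected in this assay; the expected step of no change at the digits printed from compound 2 to compound 3 (within the scatter) is therefore essentially none. For compound 3 the estimate is 2500 nM, with an expected range from 900 nM to 7000 nM.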

Compound 3, half-maximal inhibitory concentration: 1700 nM
Estimate against measurement, compound 3: 1.5-fold (0.17 log units) above, within the range that was stated.
By their numbers in this assay, from the lowest: compounds 3, 2 and 1 (each within the scatter of the next).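

In this assay, the step to (tert-butoxycarbonyl)amino on a saturated chain carbon bound to an amide-type nitrogen (a 1.5-fold lower number from compound 2 to compound 3 (0.17 log units; within the scatter)) adds a hydrogen-bond donor to a group that had none and enlarges it from 6 to 8 heavy atoms, yet the two compounds still cannot be separated. The comparison with the 3-ethylpiperidin-1-yl amide (a 1.5-fold lower number from compound 1 to compound 3 (0.18 log units; within the scatter)) also falls within the scatter, so the three different tails shown give no measurable preference at this position. The data offer no measured reason for these numbers.

From the compounds shown here alone, it remains open whether a free amine or a carboxylic acid at the end of this chain would move the number beyond the scatter. A much longer chain poses the same open question.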